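Swapping a hydroxyphenyl group on a topoisomerase inhibitor core

This account rests on a few compounds, and the source may have more. Where it says the series, first, only, none or still open, it means among the compounds named here.

Measured so far:
Compound 1 `Oc1ccc(-c2cc(-c3cccs3)cc(-c3ccccc3O)n2)cc1`: 72.2%
Compound 2 `Oc1ccccc1-c1cc(-c2ccsc2)cc(-c2ccccc2O)n1`: 0%
Compound 3 `Oc1ccccc1-c1cc(-c2ccoc2)cc(-c2ccccc2O)n1`: 1%

In an assay on isolated protein for inhibition of DNA topoisomerase 1 (Homo sapiens), with a stated time of 30 min, tested at 100 uM (on this read-out lower numbers stand for a weaker effect and higher numbers for a stronger effect at the one concentration tested), compound 3 is second highest of three numbers; its nearest neighbour is compound 2, and its furthest is compound 1. Compound 4 `Oc1ccc(-c2cc(-c3ccoc3)cc(-c3ccccc3O)n2)cc1` differs from compound 3 in one place: 4-hydroxyphenyl in place of 2-hydroxyphenyl on an aromatic carbon. For the measured compounds named here, no measured step changes this group, so none bears directly on it. Going by the values given here, the only step available, a number 1 percentage points higher from compound 2 to compound 3 (within the scatter), moved the five-membered ring instead and stayed within the scatter. Compound 1, which carries a 4-hydroxyphenyl group, gives 72.2%, whereas both 2-hydroxyphenyl compounds sit near zero. A rise is therefore expected, of about a number 34 percentage points higher from compound 3 to compound 4 (beyond the scatter), though with wide uncertainty. Compound 4 is estimated at 35%, between 2% and 72%.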

Compound 4, a percentage reported as inhibition, at one concentration (the size of the read-out at that concentration, not a potency): 30.1%
Compound 4: the middle estimate sits 4.9 percentage points above what was measured, within the range that was stated.
By their numbers in this assay, from the lowest: compounds 2 and 3 (each within the scatter of the next); then compound 4; then compound 1.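

In this assay, 4-hydroxyphenyl in place of 2-hydroxyphenyl gives a number 29.1 percentage points higher from compound 3 to compound 4 (beyond the scatter), so the same atoms joined differently at this position can separate a near-inactive compound from a clearly active one. The five-membered ring also matters in the presence of 4-hydroxyphenyl: furan-3-yl in place of thiophen-2-yl gives a number 42.1 percentage points lower from compound 1 to compound 4 (beyond the scatter), although the swap from thiophen-3-yl to furan-3-yl gave only a number 1 percentage points higher from compound 2 to compound 3 (within the scatter) with 2-hydroxyphenyl present. Nothing available explains these differences.

The large drop combines a change of ring atom with a change of attachment point, and these compounds do not separate the two. From the compounds shown here alone, whether the hydroxyl itself is needed remains open, as would be tested by a 4-aminophenyl or 4-methoxyphenyl group at this position.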